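Sulfonyl group swaps: from compound 3 to compound 4

This account rests on a few compounds, and the source may have more. Where it says the series, first, only, none or still open, it means among the compounds named here.

Measured in a physicochemical assay for solubility, in phosphate buffer, with a stated time of 24 h, at pH 7.4, tested at 100 uM; a higher number here means a more soluble compound, a lower number a less soluble compound:
- compound 1 `O=C(NCc1ccc(S(=O)(=O)C2CCC(F)(F)CC2)cc1)N1Cc2ccncc2C1` gives 35000 nM
- compound 2 `CC(=O)N1CCC(S(=O)(=O)c2ccc(CNC(=O)N3Cc4ccncc4C3)cc2)CC1` gives 187000 nM
- compound 3 `O=C(NCc1ccc(S(=O)(=O)N2CCC(O)CC2)cc1)N1Cc2ccncc2C1` gives 174000 nM

Compound 3 cannot be told apart from compound 2, since a 1.1-fold lower number from compound 2 to compound 3 (0.03 log units; within the scatter) stays within the scatter, and both stand clear of compound 1. Compound 4 `O=C(NCc1ccc(S(=O)(=O)N2CC3(CCOCC3)C2)cc1)N1Cc2ccncc2C1` carries one change: a group of 9 heavy atoms (7 carbon, 1 nitrogen, 1 oxygen; one four-membered non-aromatic ring with 1 hetero atom, one six-membered non-aromatic ring with 1 hetero atom) in place of a group of 7 heavy atoms (5 carbon, 1 nitrogen, 1 oxygen; one six-membered non-aromatic ring with 1 hetero atom), on a sulfonyl sulfur.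

The nearest evidence is a 1.1-fold lower number from compound 2 to compound 3 (0.03 log units; within the scatter), where one group exchange left the number unmoved. The modest steps of a 5.3-fold higher number from compound 1 to compound 2 (0.73 log units; beyond the scatter) and a 5.0-fold higher number from compound 1 to compound 3 (0.70 log units; beyond the scatter) both start from 4,4-difluorocyclohexyl, which does not enter here. Going by the values given here, no measured step covers the entering group, so only a slight fall in this assay is expected, not one beyond the scatter. The expected step is a 1.7-fold lower number from compound 3 to compound 4 (0.24 log units; within the scatter) and no more. Compound 4 is estimated at 100000 nM, within an expected range of 40000 nM to 200000 nM for this estimate.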

Compound 4, solubility: 272000 nM
Estimate against measurement, compound 4: 2.7-fold (0.43 log units) below, and the stated range ends below it.
By their numbers in this assay, from the lowest: compound 1; then compounds 3, 2 and 4 (each within the scatter of the next).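

With a group carrying 0 hydrogen-bond donors on the sulfonyl sulfur in place of 4-hydroxypiperidin-1-yl with its 1 hydrogen-bond donor, this assay shows a 1.6-fold higher number from compound 3 to compound 4 (0.19 log units; within the scatter) and so the donor count of this group does not separate the two compounds. The new group also stays level with 1-acetylpiperidin-4-yl in a 1.5-fold higher number from compound 2 to compound 4 (0.16 log units; within the scatter) while a 7.8-fold higher number from compound 1 to compound 4 (0.89 log units; beyond the scatter) leaves only 4,4-difluorocyclohexyl apart from the other three groups. No available evidence accounts for these results.

Still open, on these data alone, is how a basic amine such as 4-methylpiperazin-1-yl or a carboxylic acid on the sulfonyl sulfur would compare. An open dimethylamino group at this place also remains to be compared with the ring-bearing groups.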